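Exchanging the Aryl Group of Compound 1

A few compounds are considered here, and "the series" means these few. Any claim that something is new, unique, unknown or untested is made for them only; others in the source may bear on it.

In a functional assay on HL-60 cells (Homo sapiens) for cytotoxicity (on this read-out higher numbers stand for weaker inhibition and lower numbers for stronger inhibition), compound 1 `COc1ccc(/C=C\c2ccc3c(c2)C(C)(C)CCC3(C)C)cc1` gives 50000 nM. Its double-bond isomer, compound 2 `COc1ccc(/C=C/c2ccc3c(c2)C(C)(C)CCC3(C)C)cc1`, gives 50000 nM, so the two stand level. For the measured compounds named here, compound 3 `COc1ccc(/C=C(/C)c2ccc3c(c2)C(C)(C)CCC3(C)C)cc1N`, the only measured compound with an amino group, gives 42000 nM, within the scatter of compound 1.

Compound 4 `CC1(C)CCC(C)(C)c2cc(/C=C\c3cccc(N)c3)ccc21` departs from compound 1 in a single exchange: 3-aminophenyl in place of 4-methoxyphenyl on a double-bonded chain carbon bound to a double-bonded chain carbon. Only one measured step links two of these compounds, no change at the digits printed from compound 1 to compound 2 (within the scatter). It rests on (the fact that compounds 1 and 2 differ only in the configuration as drawn), so it gives no size for exchanging the aryl group. The closest guide is compound 3 at 42000 nM, which suggests that an amino group need not move the number far. No step beyond the scatter is therefore expected in this assay, though a slightly lower number is thought more likely than a higher one. The expected change is a 1.4-fold lower number from compound 1 to compound 4 (0.15 log units; within the scatter). For compound 4 the estimated value is 35000 nM, with an expected range from 10000 nM to 70000 nM.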

Compound 4, half-maximal inhibitory concentration: 10000 nM
Compound 4: middle estimate off by 3.5-fold (0.54 log units), on the high side, and the stated range covers the measured number.
By their numbers in this assay, from the lowest: compound 4; then compounds 3, 1 and 2 (each within the scatter of the next).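

For the compounds shown here, the exchange of 4-methoxyphenyl for 3-aminophenyl gives the first step beyond the scatter in this set: in this assay there is a 5.0-fold lower number from compound 1 to compound 4 (0.70 log units; beyond the scatter). The aryl group on the double-bonded chain carbon can therefore move this read-out, a modest effect that the earlier comparison of double-bond isomers, with no change at the digits printed from compound 1 to compound 2 (within the scatter), could not reveal. Nothing shown here explains the step.

The exchange removes the methoxy group, adds the amino group and alters the substitution on the ring in one move, so the compounds shown cannot assign the step to any one of these. On these data alone, it remains open whether a hydroxyl group or an acetamide in place of the amine would keep the lower number, and whether the isomer of compound 4 with its double bond drawn E would stand level with it.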